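A few compounds are considered here, and "the series" means these few. Any claim that something is new, unique, unknown or untested is made for them only; others in the source may bear on it.

Compound 1, `O=C(CN(c1nc(Cl)nc2[nH]cnc12)C1CC1)N[C@@H](CO)C(=O)OCc1ccccc1`: 31.9%
Compound 2, `NC(=O)CC[C@H](NC(=O)CN(c1ncnc2c1ncn2C1CCCCO1)C1CC1)C(=O)OCc1ccccc1`: 47%

Of the compounds shown here, two have been measured so far. In a functional assay on the whole organism (Tail, strain ICR) with Mus musculus as the target, in the tail flick test, with a stated time of 30 min, at a dose of 25 umol/kg by the oral route (a lower number here means a weaker effect, a higher number a stronger effect of the compound at the dose given), compound 1 gives 31.9%, the lower of the two numbers. Compound 2 gives 47% in this assay, and the gap between them is beyond the scatter, so compound 1 stands as the weaker of the pair. Compound 2 differs from compound 1 in several places at once, so nothing can be read from this pair about any single change.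

The next compound, compound 3, `C[C@H](NC(=O)CN(c1nc(Cl)nc2[nH]cnc12)C1CC1)C(=O)OCc1ccccc1`, differs from compound 1 in one place only: hydrogen in place of hydroxy on a saturated chain carbon, two bonds along the chain from an amide-type nitrogen and a carbonyl carbon. For the measured compounds named here, no other pair in this set shares that change, so there is no measured step to lean on. Removing a hydroxy in this way is a small change in size, and with nothing to suggest a direction, the expected change, a number 1.9 percentage points lower from compound 1 to compound 3 (within the scatter), lies within the usual scatter. Compound 3 is therefore estimated to give 30% in this assay, with a range from 14% to 46%.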

Compound 3, a percentage reported as activity, at one dose (the size of the read-out at that dose, not a potency): 41.2%
The estimate for compound 3 lay 11.2 percentage points below the measured number; the range from low to high includes it.
By their numbers in this assay, from the lowest: compounds 1, 3 and 2 (each within the scatter of the next, the first and the last beyond it).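

In this assay, for the compounds shown here, putting hydrogen in place of hydroxy on a saturated chain carbon, two bonds along the chain from an amide-type nitrogen and a carbonyl carbon, gives a number 9.3 percentage points higher from compound 1 to compound 3 (within the scatter) and is the first single-place change that can be read in this set. The two compounds cannot be told apart at the dose given, so in this one pair the read-out does not depend on the hydroxy, and the hydroxymethyl group can be cut to methyl without a loss that stands out from the scatter. Nothing measured here explains this outcome or links it to any property of the group.

The compounds shown leave open how an amine or a carboxylic acid on this same chain carbon, or a longer chain ending in either group, would read in this assay at this dose. Going by these compounds alone, they also leave open whether hydrogen in place of hydroxy would give a similar outcome on a different core, since this single pair is the only example of the change.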